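This account rests on a few compounds, and the source may have more. Where it says the series, first, only, none or still open, it means among the compounds named here.

Measured so far:
compound 1, `COc1cc(Nc2ncc(C(F)(F)F)c(N3Cc4cccc(N(C)S(C)(=O)=O)c4C3)n2)c(OC)cc1Cl`: 16500 nM
compound 2, `CN(c1cccc2c1CN(c1nc(Nc3cccc(Oc4ccccc4)c3)ncc1C(F)(F)F)C2)S(C)(=O)=O`: 4300 nM

Both were run in a functional assay on HeLa cells (Homo sapiens) for antiproliferative activity, read by spectrophotometry, with a stated time of 2 days; a lower number here means a stronger inhibitor of growth, a higher number a weaker inhibitor of growth. Compound 2 gives the lower of the two numbers; compound 1 sits higher, and that gap is beyond the usual scatter. Only two points exist, so no trend across the series can be claimed from them.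

Compound 3, `CN(c1cccc2c1CN(c1nc(Nc3cccc(C(F)(F)F)c3)ncc1C(F)(F)F)C2)S(C)(=O)=O`, is not yet measured. Relative to compound 2 the change is trifluoromethyl in place of phenoxy on an aromatic carbon: the phenoxy leaves and a trifluoromethyl enters, the change being confined to that one aromatic carbon. Among the compounds with values here, no measured pair shows this change, so its effect is unknown here.

The expectation for compound 3 is a modest move towards a higher number, the step of a 1.5-fold higher number from compound 2 to compound 3 (0.18 log units; within the scatter) judged likely to be small and possibly within the scatter. Compound 3 is estimated at 6500 nM, with a range of 2200 nM to 19000 nM.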

Compound 3, concentration for 50% growth inhibition: 5300 nM
Estimate against measurement, compound 3: 1.2-fold (0.09 log units) above; low and high end bracket the measured number.
By their numbers in this assay, from the lowest: compounds 2 and 3 (each within the scatter of the next); then compound 1.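

In this assay the step of a 1.2-fold higher number from compound 2 to compound 3 (0.09 log units; within the scatter) shows that, at this aromatic carbon meta to a large group, phenoxy and trifluoromethyl cannot be told apart, so an aromatic ring on this carbon is not required for a number in this range. The step of a 3.1-fold lower number from compound 1 to compound 3 (0.49 log units; beyond the scatter) shows that the aryl group on the nitrogen does matter as a whole, since exchanging 4-chloro-2,5-dimethoxyphenyl for 3-(trifluoromethyl)phenyl moves the number beyond the scatter. No measurement available here bears on the cause of either step.

Going by these compounds, whether an amine, a carboxylic acid or a longer alkoxy chain on the same aromatic carbon would stay in this range remains open. Also open, on these data alone, is which part of 4-chloro-2,5-dimethoxyphenyl, the chlorine or the methoxy groups, carries the step from compound 1.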